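This account rests on a few compounds, and the source may have more. Where it says the series, first, only, none or still open, it means among the compounds named here.

Of the compounds shown here, three that share one core have been measured in an assay on isolated protein (urine) for inhibition of Myeloperoxidase (Homo sapiens), read by spectrophotometry; on this read-out lower numbers stand for stronger inhibition and higher numbers for weaker inhibition. Compound 1 `COc1c2ccccc2nn1C(C)C` carries an isopropyl group on an aromatic nitrogen, and in this assay compound 1 gives 704 nM. Compound 2 `CCCCCn1nc2ccccc2c1OC` carries a pentyl group in that place, and in this assay compound 2 gives 3880 nM. Compound 3 `CCCCCCCCn1nc2ccccc2c1OCC` carries an octyl group together with an ethoxy group; in this assay compound 3 reaches only a limit of the assay, > 10000 nM, which is the limit of > 10000 nM in this assay, at which 1 of the 3 values shown sits, and not a number. Within the data shown here, of the two numbers proper, compound 2 stands highest, and the only measured step, a 5.5-fold higher number from compound 1 to compound 2 (0.74 log units; beyond the scatter), shows that a longer chain on the aromatic nitrogen went with weaker inhibition.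

Compound 4 `COc1c2ccccc2nn1CCCCO` differs from compound 2 in one place: hydroxy in place of methyl on a saturated chain carbon, four bonds along the chain from an aromatic nitrogen. Among the measured compounds shown here, no measured step exchanges a methyl for a hydroxy, so the one step of a 5.5-fold higher number from compound 1 to compound 2 (0.74 log units; beyond the scatter) bears on it only loosely, in that the hydroxy end leaves a shorter stretch of carbon than the pentyl of compound 2. The step from compound 2 to compound 4 is therefore expected to be small, a 1.6-fold lower number from compound 2 to compound 4 (0.19 log units; within the scatter), leaning toward stronger inhibition. In this assay compound 4 is estimated at 2500 nM, within a range from 800 nM to 8000 nM.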

Compound 4, half-maximal inhibitory concentration: 1790 nM
Estimate against measurement, compound 4: 1.4-fold (0.15 log units) above, and the stated range covers the measured number.
By their numbers in this assay, from the lowest: compound 1; then compound 4; then compound 2. At a limit, above all of these: compound 3.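

Placing hydroxy in place of methyl on a saturated chain carbon, four bonds along the chain from an aromatic nitrogen, gives in this assay a 2.2-fold lower number from compound 2 to compound 4 (0.34 log units; beyond the scatter) and so shows that exchanging this single atom moves the number toward stronger inhibition. The weaker inhibition seen with the pentyl chain of compound 2 is therefore not fixed for every chain of this kind, yet 4-hydroxybutyl still falls short of isopropyl on the aromatic nitrogen, with a 2.5-fold higher number from compound 1 to compound 4 (0.41 log units; beyond the scatter) as the gap that remains. Nothing measured here gives a reason for either shift.

The compounds shown leave open whether an amine or a carboxylic acid at the end of the chain would move the number further in the same direction, and whether a shorter chain such as 2-hydroxyethyl or 3-hydroxypropyl would close the distance to compound 1. They also leave open whether a methoxy group at that chain end, which keeps the oxygen but lacks the hydroxy hydrogen, would match compound 4.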